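Acyl group reduction on the shared core: compound 3

A few compounds are considered here, and "the series" means these few. Any claim that something is new, unique, unknown or untested is made for them only; others in the source may bear on it.

Compound 2 `C[C@H]1C[C@@H]1C(=O)N1CC2CNCC2C1` stands lowest of the two measured numbers in an assay on SHEP1 cells for agonist activity at Neuronal acetylcholine receptor; alpha4/beta2 (Homo sapiens), read by FLIPR and calcium flux; a lower number here means a smaller maximal response, a higher number a larger maximal response; compound 2 gives 68%. Its stereoisomer compound 1 `C[C@@H]1C[C@@H]1C(=O)N1CC2CNCC2C1` gives 140% in this assay, so the step of a number 72 percentage points lower from compound 1 to compound 2 (beyond the scatter) is large, and it is tied to the fact that one of compounds 1 and 2 is drawn with a defined configuration and the other without, at the place where they differ, a single stereocentre within the 2-methylcyclopropyl. Compound 3 `CC(=O)N1CC2CNCC2C1` is not yet measured; the change from compound 2 is methyl in place of 2-methylcyclopropyl on a carbonyl carbon. Among the measured compounds shown here, no measured step alters the acyl group itself, so only the stereo step bears on this change, and only indirectly: two compounds identical except in one centre differ widely, which leaves the direction for a methyl, carrying no stereocentre, open. The step expected is a number 27 percentage points higher from compound 2 to compound 3 (beyond the scatter), with the usual scatter well exceeded in either direction possible. Compound 3 is expected at 95%, in the range 40% to 150%.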

Compound 3, largest response reached (Emax), in percent of the reference or control that the assay uses: 110%
For compound 3 the middle estimate is 15 percentage points below the measured one; the measured number falls inside the stated range.
By their numbers in this assay, from the lowest: compound 2; then compound 3; then compound 1.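

In this assay the acyl position now shows a change of group, not only of configuration: methyl in place of 2-methylcyclopropyl on the carbonyl carbon gives a number 42 percentage points higher from compound 2 to compound 3 (beyond the scatter), while the same change set against the other stereoisomer gives a number 30 percentage points lower from compound 1 to compound 3 (beyond the scatter). The change therefore has no single direction, as its sign depends on the stereoisomer it starts from, and compound 3, with no ring and no stereocentre in the acyl group, lies between the two. The 2-methylcyclopropyl is thus not required for a high maximal response, and what separates the two stereoisomers remains only this: the fact that one of compounds 1 and 2 is drawn with a defined configuration and the other without, at the place where they differ

Whether the ring or the number of carbons sets the response stays open, as the compounds shown do not separate the two. An unsubstituted cyclopropyl or an ethyl on the same carbonyl carbon would bear directly on this.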